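Replacing the amide aryl group with a dimethylaminoethyl chain

A few compounds are considered here, and "the series" means these few. Any claim that something is new, unique, unknown or untested is made for them only; others in the source may bear on it.

Compound 1, `Cc1ccccc1NC(=O)CCC(=O)OCCCCCCSc1ccc([N+](=O)[O-])c2nonc12`, gives 440 nM in an assay on isolated protein for inhibition of glutathione S-transferase Mu 2 (Homo sapiens), with a stated time of 10 min; on this read-out higher numbers stand for weaker inhibition and lower numbers for stronger inhibition.
Compound 2, `Cc1ccc(NC(=O)CCC(=O)OCCCCCCSc2ccc([N+](=O)[O-])c3nonc23)cc1`, gives 390 nM in this assay.

Compound 2 has the lowest of the two numbers, and its nearest neighbour is compound 1, yet the step of a 1.1-fold lower number from compound 1 to compound 2 (0.05 log units; within the scatter) lies within the scatter, so the two cannot be ordered. Compound 3, `CN(C)CCNC(=O)CCC(=O)OCCCCCCSc1ccc([N+](=O)[O-])c2nonc12`, differs from compound 2 by 2-(dimethylamino)ethyl in place of 4-methylphenyl on an amide-type nitrogen. Among the compounds with values here, only one measured step exists, and it concerns the position of a methyl group on an aromatic ring, not the exchange of an aryl group for an open chain bearing a nitrogen; it bears on the new step only distantly. The data therefore give no direct guide, and the expected step of a 1.8-fold higher number from compound 2 to compound 3 (0.25 log units; within the scatter) is a cautious one with wide uncertainty. For compound 3 the estimate in this assay is 700 nM, with a range from 200 nM to 2500 nM.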

Compound 3, half-maximal inhibitory concentration: 160 nM
Estimate against measurement, compound 3: 4.4-fold (0.64 log units) above, and the stated range ends above it.
By their numbers in this assay, from the lowest: compound 3; then compounds 2 and 1 (each within the scatter of the next).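

At this amide-type nitrogen an aromatic ring is not needed for inhibition: in this assay, 2-(dimethylamino)ethyl in place of 4-methylphenyl gives a 2.4-fold lower number from compound 2 to compound 3 (0.39 log units; beyond the scatter), and in place of 2-methylphenyl it gives a 2.8-fold lower number from compound 1 to compound 3 (0.44 log units; beyond the scatter). Both steps are modest but lie beyond the scatter, so compound 3 is the strongest inhibitor of the three, and this change moves the number more than the shift of the methyl group did. Nothing available explains why the open chain gives the lower number.

Compound 3 loses the aromatic ring and gains the dimethylamino nitrogen in one step, so the two changes cannot be separated. A plain butyl chain, a morpholine at the end of the ethyl chain or a longer chain ending in the same amine would each bear on that question.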